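Swapping a hydroxylated chain for a methoxyethoxy chain

A few compounds are considered here, and "the series" means these few. Any claim that something is new, unique, unknown or untested is made for them only; others in the source may bear on it.

In an ADME assay on HEp-2 cells (Homo sapiens) for cytotoxicity, with a stated time of 4 days (on this read-out higher numbers stand for lower toxicity in this test and lower numbers for higher toxicity in this test), compound 1 `CC(C)(O)CCn1c(Cn2nc(S(C)(=O)=O)c3ccncc32)nc2cc(Cl)ccc21` gives > 100000 nM, which is a limit of the test and not a number.
Compound 2 `CC(C)(CO)Cn1c(Cn2nc(S(C)(=O)=O)c3ccncc32)nc2cc(Cl)ccc21` gives > 100000 nM in this assay, again a limit.

Among the compounds with values here, compound 2 therefore stands at the limit, and the one step that reaches it, a step that the two limits leave unreadable from compound 1 to compound 2, cannot be sized. Compound 3 `COCCOCCn1c(Cn2nc(S(C)(=O)=O)c3ccncc32)nc2cc(Cl)ccc21` differs from compound 2 by (2-methoxyethoxy)methyl in place of 1-(hydroxymethyl)-1-methylethyl on a saturated chain carbon bound to an aromatic nitrogen. Within the data shown here, the only measured step bearing on this position is the one from compound 1 to compound 2, and it is unreadable; the sole evidence is the limit of > 100000 nM in this assay, at which 2 of the 2 values shown sit. Both values sitting at the limit suggest that this chain position tolerates change without any toxicity appearing, so compound 3 is expected to show no step beyond the scatter, a step that the limit leaves unreadable from compound 2 to compound 3. Compound 3 is estimated at 150000 nM, most likely reported again as a limit.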

Compound 3, half-maximal cytotoxic concentration: > 100000 nM
Compound 3 ended at the assay's limit; the forecaster's own chance of this, stated with the estimate: 85%; the middle value does not contradict the limit.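

Compound 1, compound 2 and compound 3 all give a limit of the test and not a number, so none of the steps among them can be read. The compounds shown leave open whether these three differ at all in this assay, and whether any chain at this place would give a readable value.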